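Working notes: amide aryl change, compound 2 to compound 3

A few compounds are considered here, and "the series" means these few. Any claim that something is new, unique, unknown or untested is made for them only; others in the source may bear on it.

Measured so far:
compound 1 `COC(=O)c1scc(-c2ccc(NC(=O)c3ccccn3)cc2)c1OC`: 8250 nM
compound 2 `COC(=O)c1scc(-c2ccc(NC(=O)c3ccc(F)c(Cl)n3)cc2)c1OC`: 10300 nM

Going by the values given here, in a functional assay on MDA-MB-231 cells (Homo sapiens) for antiproliferative activity, read by MTT assay, with a stated time of 24 h (on this read-out higher numbers stand for weaker inhibition and lower numbers for stronger inhibition), compound 2 gives 10300 nM, numerically the higher of the two values shown, though the only measured step, a 1.2-fold higher number from compound 1 to compound 2 (0.10 log units; within the scatter), lies within the scatter, so the two compounds cannot be separated. Compound 3 `COC(=O)c1scc(-c2ccc(NC(=O)c3ccc(C(F)(F)F)cc3)cc2)c1OC` is not yet measured. It differs from compound 2 in one place: 4-(trifluoromethyl)phenyl in place of 6-chloro-5-fluoropyridin-2-yl on a carbonyl carbon. Among the compounds with values here, the one step that bears on this change is at the same carbonyl carbon, a 1.2-fold higher number from compound 1 to compound 2 (0.10 log units; within the scatter), which swapped one six-membered aromatic ring with 1 hetero atom for another without a shift beyond the scatter. Within the data shown here, no measured step covers a six-membered aromatic ring of carbon only in this place, so the expectation rests on that single step. Compound 3 is therefore expected to show a step of a 1.1-fold lower number from compound 2 to compound 3 (0.06 log units; within the scatter), nothing beyond the scatter in either direction. The estimate for compound 3 in this assay is 9000 nM, within a range of 3000 nM to 30000 nM.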

Compound 3, half-maximal inhibitory concentration: 18300 nM
For compound 3 the middle estimate is 2.0-fold (0.31 log units) below the measured one; low and high end bracket the measured number.
By their numbers in this assay, from the lowest: compounds 1, 2 and 3 (each within the scatter of the next, the first and the last beyond it).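

In this assay, replacing 6-chloro-5-fluoropyridin-2-yl with 4-(trifluoromethyl)phenyl on this carbonyl carbon gives a 1.8-fold higher number from compound 2 to compound 3 (0.25 log units; within the scatter) and so does not separate those two groups. Going by these compounds alone, measured against pyridin-2-yl, the same group gives a 2.2-fold higher number from compound 1 to compound 3 (0.35 log units; beyond the scatter) and this is the first step at this position to pass the scatter, so a ring of carbon only is tolerated here with a modest loss of inhibition at most. No measurement at hand explains this step.

Plain phenyl at this place would show whether the step from pyridin-2-yl follows the ring change or the trifluoromethyl group. Also open is how an aliphatic amine or a carboxylic acid on this ring would read out, since all three groups shown are neutral aromatic rings.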